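Removing Chloro from a Scaffold That Shows No Response

The source may report more compounds than this note shows. Statements on the series, on what has been measured and on what is new or still open speak of the compounds shown alone.

Compound 1 `Fc1cc(Cl)ccc1N1CCN(Cc2ccn3c(CC4CC4)nnc3c2C(F)(F)F)CC1` was examined in a functional assay on HEK293 cells for agonist activity at metabotropic glutamate receptor 6 (Homo sapiens), read by a luciferase reporter and cAMP accumulation; on this read-out higher numbers stand for an effect only at larger amounts of compound and lower numbers for an effect already at smaller amounts. There compound 1 reaches only the limit of the assay, > 10000 nM. Compound 2 `Fc1ccc(C2CCN(Cc3ccn4c(CC5CC5)nnc4c3C(F)(F)F)CC2)c(F)c1` likewise reaches only the limit, > 10000 nM, in this assay. Compound 1 thus stands at the limit of > 10000 nM in this assay, at which 2 of the 2 values shown sit, with no number to place it against. Compound 3 `Fc1ccccc1N1CCN(Cc2ccn3c(CC4CC4)nnc3c2C(F)(F)F)CC1` differs from compound 1 by hydrogen in place of chloro on an aromatic carbon. With both known values at the limit, a step that the limit leaves unreadable from compound 1 to compound 3 in this assay is expected to remain within the scatter. Compound 3 is accordingly expected to give 15000 nM, between 5000 nM and 50000 nM, most likely again only a limit.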

Compound 3, half-maximal effective concentration: > 10000 nM
Compound 3 ended at the assay's limit; the forecaster's own chance of this, stated with the estimate: 85%; the middle value does not contradict the limit.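

Among these compounds, compound 1 and compound 3 both give only a limit in this assay, so no step between them can be read: the limit of > 10000 nM in this assay, at which 3 of the 3 values shown sit. The compounds shown leave open whether losing chloro changes the response at all.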